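Removing the Chloro Group From a Weakly Cytotoxic Triazole

A few compounds are considered here, and "the series" means these few. Any claim that something is new, unique, unknown or untested is made for them only; others in the source may bear on it.

Compound 1 `C=C1C(=O)[C@]23C[C@@]1(O)CC[C@H]2c1ccc(OS(=O)(=O)c2ccc(C)cc2)c(C)c1[C@@H]3Cn1cc(-c2ccc(Br)cc2)nn1` gives 4320 nM in a functional assay on SMMC-7721 cells (Homo sapiens) for cytotoxicity, read by MTT assay, with a stated time of 4 days; a higher number here means a weaker inhibitor, a lower number a stronger inhibitor. Compound 2 `C=C1C[C@]23C[C@@]1(O)CC[C@@H]2c1cccc(C)c1[C@@H]3Cn1cc(-c2ccc(Cl)cc2)nn1` reaches only a limit of the assay, > 20000 nM in this assay. Compound 2 thus sits at the limit of > 20000 nM in this assay, at which 1 of the 2 values shown sits, the weaker end of the two values, with no exact number. Compound 3 `C=C1C[C@]23C[C@@]1(O)CC[C@@H]2c1cccc(C)c1[C@@H]3Cn1cc(-c2ccccc2)nn1` differs from compound 2 by hydrogen in place of chloro on an aromatic carbon. Within the data shown here, no measured pair shows this change. The step that the limit leaves unreadable from compound 2 to compound 3 is expected to be small, not beyond the scatter, in either direction. Compound 3 is therefore expected to give about 30000 nM, within 8000 nM to 100000 nM, most likely again only a limit.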

Compound 3, half-maximal inhibitory concentration: > 20000 nM
Compound 3: no number, only a limit; the forecaster's own chance of this, stated with the estimate: 80%; the middle value is on the limit's open side.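

Compound 2 and compound 3 both stop at a limit of the assay, not at a number, so no step between them can be read: the limit of > 20000 nM in this assay, at which 2 of the 3 values shown sit.

As far as these compounds go, what hydrogen in place of chloro does in this assay stays open, as does how far either compound lies past that limit.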